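The source may report more compounds than this note shows. Statements on the series, on what has been measured and on what is new or still open speak of the compounds shown alone.

Measured compounds in an ADME assay on 184B5 cells (Homo sapiens) for cytotoxicity, read by MTT assay, with a stated time of 72 h; on this read-out higher numbers stand for weaker inhibition of growth and lower numbers for stronger inhibition of growth:
- compound 1 `COc1ccc(CNc2nc([Se]C)nc3ccccc23)cc1`: 75600 nM
- compound 2 `COc1ccc(CNc2nc([SeH])nc3ccccc23)cc1`: 71300 nM
- compound 3 `CSc1ccc(CNc2nc([SeH])nc3ccccc23)cc1`: 6840 nM

Compound 1 gives the highest number of the three in this assay. Compound 2 sits within the scatter of it, a 1.1-fold lower number from compound 1 to compound 2 (0.03 log units; within the scatter), so the hydrogen in place of methyl on the selenium changes nothing that can be read. Going by the values given here, compound 3 stands furthest from compound 1, and the one step that leads to it, a 10-fold lower number from compound 2 to compound 3 (1.02 log units; beyond the scatter), is the only large movement; it comes from methylsulfanyl in place of methoxy on an aromatic carbon.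

Compound 4 `C[Se]c1nc(NCc2ccccc2)c2ccccc2n1` is not yet measured. Against compound 1 it differs by hydrogen in place of methoxy on an aromatic carbon. Among the compounds with values here, no measured step removes a group at this place; the step from compound 2 to compound 3 only shows that an exchange at this carbon can move the number strongly, and the step from compound 1 to compound 2 shows that the selenium end is indifferent. For compound 4 the number in this assay is therefore expected to stay close to that of compound 1, with a 1.3-fold lower number from compound 1 to compound 4 (0.10 log units; within the scatter) as the estimated step. The estimate for compound 4 is 60000 nM, within a range of 20000 nM to 150000 nM.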

Compound 4, concentration for 50% growth inhibition: 3720 nM
Estimate against measurement, compound 4: 16-fold (1.21 log units) above, and the stated range ends above it.
By their numbers in this assay, from the lowest: compounds 4 and 3 (each within the scatter of the next); then compounds 2 and 1 (each within the scatter of the next).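

In this assay, the carbon para to a large group responds strongly even when the methoxy is replaced by hydrogen alone, with no new group entering: a 20-fold lower number from compound 1 to compound 4 (1.31 log units; beyond the scatter) is a large step. Until now, the only large movement at this carbon was an exchange of one group for another, a 10-fold lower number from compound 2 to compound 3 (1.02 log units; beyond the scatter), so the lower number does not depend on introducing methylsulfanyl, and both steps away from methoxy run in the same direction, with no compound shown going against this. No measurement at hand bears on why removing the methoxy has this effect.

Open, on these data alone, is whether the high number belongs to methoxy alone or would also appear with an amine, a hydroxyl or a longer chain such as ethoxy on this carbon. Also open, as far as these compounds go, is whether hydrogen in place of methyl on the selenium remains as indifferent with hydrogen or methylsulfanyl on the aromatic carbon, since that step has been read only with methoxy in place.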